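A few compounds are considered here, and "the series" means these few. Any claim that something is new, unique, unknown or untested is made for them only; others in the source may bear on it.

Compound 3 `C[C@@H](NC(=O)c1ccc(C#Cc2cccc(F)n2)cn1)C(C)(C)O` gives 63% in a functional assay on HEK293 cells for positive allosteric modulation of metabotropic glutamate receptor 5 (Rattus norvegicus), read by fluorescence and calcium flux; on this read-out higher numbers stand for larger maximal responses and lower numbers for smaller maximal responses. On the numbers shown it stands second highest of three, with both neighbours within the scatter: compound 1 `Cc1ccccc1C#Cc1ccc(C(=O)N[C@H](C)C(C)(C)O)nc1` gives 59.9% and compound 2 `Cc1cccc(C#Cc2ccc(C(=O)N[C@H](C)C(C)(C)O)nc2)c1` gives 68.6%. Compound 4 `C[C@@H](NC(=O)c1ccc(C#Cc2cc(F)ccn2)cn1)C(C)(C)O` differs from compound 3 by 4-fluoropyridin-2-yl in place of 6-fluoropyridin-2-yl on a triple-bonded carbon. For the measured compounds named here, two measured steps bear on this, since each changed the group on that same triple-bonded carbon: a number 3.1 percentage points higher from compound 1 to compound 3 (within the scatter) and a number 5.6 percentage points lower from compound 2 to compound 3 (within the scatter). Neither moved the largest response beyond the scatter, and here the two compounds even keep the same atoms, joined differently. The step from compound 3 to compound 4 is therefore expected to be no change beyond the scatter, about no change at the digits printed from compound 3 to compound 4 (within the scatter). Compound 4 is estimated at 63%, with a range from 52% to 74%.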

Compound 4, largest response reached (reported as efficacy), in percent of the reference or control that the assay uses: 66.2%
The estimate for compound 4 lay 3.2 percentage points below the measured number; the measured number falls inside the stated range.
By their numbers in this assay, from the lowest: compounds 1, 3, 4 and 2 (each within the scatter of the next).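

Swapping 6-fluoropyridin-2-yl for 4-fluoropyridin-2-yl on the triple-bonded carbon keeps the same atoms but joins them differently, and it gives a number 3.2 percentage points higher from compound 3 to compound 4 (within the scatter). Set against the methylphenyl compounds, the new group gives a number 2.4 percentage points lower from compound 2 to compound 4 (within the scatter) and a number 6.3 percentage points higher from compound 1 to compound 4 (within the scatter), so all four groups shown at this position lie within the scatter of one another. No measurement shown here explains this shared largest response. From the compounds shown here alone, whether an amine or a carboxylic acid on that triple-bonded carbon would move the response beyond the scatter remains open.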